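A few compounds are considered here, and "the series" means these few. Any claim that something is new, unique, unknown or untested is made for them only; others in the source may bear on it.

Compound 1, `Cc1nc(-c2ccsc2)sc1COc1ccc2c(c1)OCC2CC(=O)O`: 68.5 nM
Compound 2, `Cc1ccc(-c2nc(C)c(COc3ccc4c(c3)OCC4CC(=O)O)s2)cc1`: 73.5 nM
Compound 3, `Cc1nc(-c2cccc(Cl)c2)sc1COc1ccc2c(c1)OCC2CC(=O)O`: 138 nM

In a functional assay on CHO cells for agonist activity at Free fatty acid receptor 1 (Homo sapiens), read by FLIPR and calcium flux (on this read-out higher numbers stand for an effect only at larger amounts of compound and lower numbers for an effect already at smaller amounts), compound 3 gives the highest of the three numbers, yet its steps from compound 1 a 2.0-fold higher number from compound 1 to compound 3 (0.30 log units; within the scatter) and from compound 2 a 1.9-fold higher number from compound 2 to compound 3 (0.27 log units; within the scatter) both stay within the scatter, so the three aryl groups read as indistinguishable here. Compound 4, `Cc1nc(-c2cccc(F)c2)sc1COc1ccc2c(c1)OCC2CC(=O)O`, carries fluoro in place of chloro on an aromatic carbon. For the measured compounds named here, no measured pair shows a halogen swap of this kind; the steps that exist only show that exchanging the whole aryl group moves this assay little. Compound 4 is therefore expected to sit close to compound 3, with a step of a 1.3-fold lower number from compound 3 to compound 4 (0.10 log units; within the scatter) that is not beyond the scatter. Compound 4 is estimated at 110 nM, between 50 nM and 250 nM.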

Compound 4, half-maximal effective concentration: 64.8 nM
Beside the measured number, compound 4's estimate is 1.7-fold (0.23 log units) above it; the range from low to high includes it.
By their numbers in this assay, from the lowest: compounds 4, 1, 2 and 3 (each within the scatter of the next, the first and the last beyond it).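

For the compounds shown here, exchanging 3-chlorophenyl for 3-fluorophenyl gives the first step in this assay that lies beyond the scatter (a 2.1-fold lower number from compound 3 to compound 4 (0.33 log units; beyond the scatter)), a modest one, so one halogen on this ring can register where the whole-aryl exchanges among compound 1, compound 2 and compound 3 did not. Against the other aryl groups, the 3-fluorophenyl group shows no separation (a 1.1-fold lower number from compound 2 to compound 4 (0.05 log units; within the scatter) and a 1.1-fold lower number from compound 1 to compound 4 (0.02 log units; within the scatter)), both within the scatter. No measurement at hand accounts for the halogen step.

On these data alone, whether bromo, methoxy or nitrile at this same place would read with chloro or with fluoro stays open.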